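Swapping the amide substituent: from tert-butyl to phenyl

The source may report more compounds than this note shows. Statements on the series, on what has been measured and on what is new or still open speak of the compounds shown alone.

Measured so far:
compound 1 `CCc1c(C)n(C(=O)N2CCCCC2)oc1=O`, 18 nM
compound 2 `Cc1c(C(C)C)c(=O)on1C(=O)N1CCCCC1`, 2 nM
compound 3 `Cc1c(C(C)C)c(=O)on1C(=O)NC(C)(C)C`, > 1000 nM

All three compounds were tested in an assay (strain Wistar) for inhibition of Hormone-sensitive lipase (Rattus norvegicus), read by spectrophotometry; on this read-out lower numbers stand for stronger inhibition and higher numbers for weaker inhibition. Compound 3 gives only a limit of the assay, > 1000 nM, so its true value is not known; it stands at the limit of > 1000 nM in this assay, at which 1 of the 3 values shown sits. Among the numbers that are known, compound 2 gives 2 nM and compound 1 gives 18 nM.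

Two measured steps lead to compound 3. The first, a 9.0-fold lower number from compound 1 to compound 2 (0.95 log units; beyond the scatter), was modest. The second, an at least 500-fold higher number from compound 2 to compound 3 (2.69 log units; beyond the scatter), was large and in the opposite direction.

Compound 4 `Cc1c(C(C)C)c(=O)on1C(=O)Nc1ccccc1` is not yet measured. It differs from compound 3 in one place: phenyl in place of tert-butyl on an amide-type nitrogen. The amide-type nitrogen keeps its hydrogen, and only the group on that nitrogen changes. Among the compounds with values here, the one measured step that touches this part of the molecule is the large one from compound 2 to compound 3, and it tells how much the group on the carbonyl carbon can matter, but not how a phenyl compares with a tert-butyl. With no measured guide for that exchange, compound 4 is expected to stay weak, the estimated step being a step that the limit leaves unreadable from compound 3 to compound 4. The estimate for compound 4 in this assay is 2000 nM, within a range from 300 nM to 10000 nM.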

Compound 4, half-maximal inhibitory concentration: > 1000 nM
Compound 4 gave a limit, no number (the forecaster's own chance of this, stated with the estimate: 55%); the middle value lies beyond the limit too.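

Compound 3 and compound 4 both give only a limit in this assay, so no step between them can be read: the limit of > 1000 nM in this assay, at which 2 of the 4 values shown sit.

The compounds shown leave open how the true values of compound 3 and compound 4 compare, and so whether phenyl or tert-butyl on the amide-type nitrogen gives the stronger inhibition.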